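The source may hold more compounds than are shown below. What is called first, only, known or untested is meant among the compounds shown, and "the series" means these compounds.

In an ADME assay on microsomes from liver (Rattus norvegicus) for metabolic stability, read by LC-MS, tested at 1 uM (a higher number here means that the compound lasts longer, a lower number that the compound disappears faster), compound 1 (`Nc1ncnc2c1c(Oc1cccc(Cl)c1)nn2CC1CCNC(=O)C1`) gives > 1 h as a limit, not a number. Compound 2 (`Nc1ncnc2c1c(Oc1cccc(Cl)c1)nn2CC1CCNCC1`) gives > 1 h as a limit too. Going by the values given here, compound 3 (`Nc1ncnc2c1c(Oc1cccc(Cl)c1)nn2CC1(C(F)(F)F)CC1`) gives 0.183 h as the only true number of the three and stands lowest of them.

Compound 4 (`Nc1ncnc2c1c(Oc1cccc(Cl)c1)nn2CC1CCCNC1`) is not yet measured, and the change leading to it is this: piperidin-3-yl in place of 1-(trifluoromethyl)cyclopropyl on a saturated chain carbon bound to an aromatic nitrogen. Two measured steps run the same kind of exchange in reverse. The step of an at least 5.4-fold lower number from compound 2 to compound 3 (0.73 log units; beyond the scatter) has piperidin-4-yl leaving, and the step of an at least 5.4-fold lower number from compound 1 to compound 3 (0.73 log units; beyond the scatter) has 2-oxopiperidin-4-yl leaving. Among the compounds with values here, both sizes are bounds, and piperidin-3-yl itself has no measured step yet.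

In this assay a rise of at least modest size is therefore expected, the reverse of those two steps. The estimated step is a 6.6-fold higher number from compound 3 to compound 4 (0.82 log units; beyond the scatter) in that direction. For compound 4 the estimate is 1.2 h with an expected range from 0.5 h to 3 h and a good chance of a reading that is only a limit.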

Compound 4, half-life: > 1 h
Compound 4 gave a limit, no number; the forecaster's own chance of this, stated with the estimate: 70%; the middle value is on the limit's open side.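

In this assay, piperidin-3-yl in place of 1-(trifluoromethyl)cyclopropyl on a saturated chain carbon bound to an aromatic nitrogen gives an at least 5.4-fold higher number from compound 3 to compound 4 (0.73 log units; beyond the scatter), so this change now has a directly observed step to a piperidine group. The piperidin-3-yl group of compound 4 joins the piperidin-4-yl group of compound 2 and the 2-oxopiperidin-4-yl group of compound 1 at the same limit, leaving compound 3 as the exception. The steps among compounds 1, 2 and 4 cannot be read because all three sit at that limit: the limit of > 1 h in this assay, at which 3 of the 4 values shown sit.

The compounds shown leave open how these three rank beyond the limit. They also leave open whether a cyclohexyl group, with carbon only in the ring, or an open-chain amine at this place would stay at the limit or fall towards compound 3.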